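Shrinking the lactone ring of compound 1

The source may report more compounds than this note shows. Statements on the series, on what has been measured and on what is new or still open speak of the compounds shown alone.

Measured in a functional assay on A549 cells (Homo sapiens) for antiproliferative activity; a higher number here means a weaker inhibitor of growth, a lower number a stronger inhibitor of growth:
compound 1 `CC/C=C\[C@H](C)[C@H](OC(N)=O)[C@@H](C)[C@H](O)[C@@H](C)C/C(C)=C\[C@H](C)[C@@H](O)[C@@H](C)/C=C\[C@@H](O)C[C@@H]1OC(=O)[C@H](C)C[C@H]1C` gives 50 nM
compound 2 `CC/C=C\[C@H](C)[C@H](OC(N)=O)[C@@H](C)[C@H](O)[C@@H](C)C/C(C)=C\[C@H](C)[C@@H](O)[C@@H](C)/C=C\[C@@H](O)C[C@@H]1OC(=O)[C@H](C)[C@@H](OC)[C@H]1C` gives 12 nM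
compound 3 `CC/C=C\[C@H](C)[C@H](OC(N)=O)[C@@H](C)[C@H](O)[C@@H](C)C/C(C)=C\[C@H](C)[C@@H](O)[C@@H](C)/C=C\[C@@H](O)C[C@@H]1OC(=O)[C@H](C)[C@@H](O)[C@H]1C` gives "not determined" (no result reported)

Among the measured compounds shown here, compound 1 stands as the higher of the two numbers; the only measured step, a 4.2-fold lower number from compound 1 to compound 2 (0.62 log units; beyond the scatter), comes from a methoxy on a saturated ring carbon. Compound 4 `CC/C=C\[C@H](C)[C@H](OC(N)=O)[C@@H](C)[C@H](O)[C@@H](C)C/C(C)=C\[C@H](C)[C@@H](O)[C@@H](C)/C=C\[C@H](O)C[C@@H]1CCC(=O)O1` differs from compound 1 by a group of 9 heavy atoms (6 carbon, 3 oxygen; one five-membered non-aromatic ring with 1 hetero atom) in place of a group of 12 heavy atoms (9 carbon, 3 oxygen; one six-membered non-aromatic ring with 1 hetero atom), on a double-bonded chain carbon bound to a double-bonded chain carbon. For the measured compounds named here, no measured step touches this change: the lactone ring itself is altered and two stereocentres are lost, which is a far larger change than the methoxy step. A weakening beyond the scatter is therefore expected, of uncertain size. Compound 4 is expected to give 500 nM, within 100 nM to 3000 nM. This estimate means a step of a 10-fold higher number from compound 1 to compound 4 (1.00 log units; beyond the scatter).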

Compound 4, concentration for 50% growth inhibition: 10000 nM
The estimate for compound 4 lay 20-fold (1.30 log units) below the measured number; the measured number lies above the stated range.
By their numbers in this assay, from the lowest: compound 2; then compound 1; then compound 4.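

In this assay, putting the five-membered ring group in place of the six-membered ring group brings a 200-fold higher number from compound 1 to compound 4 (2.30 log units; beyond the scatter) and shows that this end of the molecule tolerates far less change than the methoxy step alone suggested. The two groups have the same counts of hydrogen-bond donors and acceptors, yet they differ in ring size, carbon count and defined stereocentres, and this single step cannot separate those changes. Nothing here explains the loss. Still open, on these data alone, is whether a five-membered ring carrying methyl groups would restore activity, and how an open-chain carboxylic acid or an amide would behave at this place.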